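From isopropyl to methoxymethyl: estimating what remains

The source may hold more compounds than are shown below. What is called first, only, known or untested is meant among the compounds shown, and "the series" means these compounds.

compound 1 `C[C@@H](O)Cc1cc(-c2ccnc3[nH]nc(C(F)(F)F)c23)cc(C2(C#N)CC2)c1`: 42%
compound 2 `CCC(O)Cc1cc(-c2ccnc3[nH]nc(C(F)(F)F)c23)cc(C2(C#N)CC2)c1`: 17%
compound 3 `CC(C)C(O)Cc1cc(-c2ccnc3[nH]nc(C(F)(F)F)c23)cc(C2(C#N)CC2)c1`: 19%

These three compounds share one core and differ in a single group: 1-hydroxyethyl in compound 1, 1-hydroxypropyl in compound 2 and 1-hydroxy-2-methylpropyl in compound 3. In an ADME assay on S9 fraction from liver (Rattus norvegicus) for metabolic stability, read by LC-MS, using NADPH, with a stated time of 60 min, tested at 10 uM (a lower number here means that less of the compound is left, a higher number that more of the compound is left), compound 3 gives 19%. It cannot be told apart from its nearest neighbour, as the step is within the scatter: a number 2 percentage points higher from compound 2 to compound 3 (within the scatter). Compound 1 stands apart from both, with clear drops in the other two: a number 25 percentage points lower from compound 1 to compound 2 (beyond the scatter) and a number 23 percentage points lower from compound 1 to compound 3 (beyond the scatter).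

The next compound is compound 4 `COCC(O)Cc1cc(-c2ccnc3[nH]nc(C(F)(F)F)c23)cc(C2(C#N)CC2)c1`, which has methoxymethyl in place of isopropyl on a saturated chain carbon bound to an oxygen on a saturated carbon and a saturated chain carbon. The same change can be read as 1-hydroxy-2-methoxyethyl replacing 1-hydroxy-2-methylpropyl.

Among the compounds with values here, no measured step puts an oxygen into this group, so the data offer no direct guide. The closest comparison is the small change between compound 2 and compound 3, while the larger drops from compound 1 show that this group can matter. In this assay the expected result is therefore a number 3 percentage points higher from compound 3 to compound 4 (within the scatter), with a wide margin. Compound 4 is estimated at 22%, with an expected range of 8% to 42%.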

Compound 4, percent of the compound remaining: 51%
Estimate against measurement, compound 4: 29 percentage points below, and the stated range ends below it.
By their numbers in this assay, from the lowest: compounds 2 and 3 (each within the scatter of the next); then compounds 1 and 4 (each within the scatter of the next).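

In this assay this position responds to the kind of atom in the group and not only to its size: methoxymethyl and isopropyl each have 3 heavy atoms, yet the swap gives a number 32 percentage points higher from compound 3 to compound 4 (beyond the scatter), and methoxy in place of methyl gives a number 34 percentage points higher from compound 2 to compound 4 (beyond the scatter). The earlier compounds shown here could suggest that anything larger than 1-hydroxyethyl lowers the amount left, but compound 4 goes against that, since its larger 1-hydroxy-2-methoxyethyl group cannot be told apart from the group of compound 1, with a number 9 percentage points higher from compound 1 to compound 4 (within the scatter). No measurement available here explains how the oxygen produces this difference.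

The compounds shown leave open whether the result is specific to methoxymethyl or would carry over to an ethoxymethyl, a fluoromethyl or a dimethylaminomethyl group at the same place. They also leave open how much the arrangement at the hydroxyl-bearing carbon matters, as compound 1 is drawn as a single mirror-image form, whereas compound 4 is drawn without one.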